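The source may hold more compounds than are shown below. What is called first, only, known or untested is meant among the compounds shown, and "the series" means these compounds.

Measured compounds in a functional assay for inhibition of nuclear factor NF-kappa-B complex (Homo sapiens); on this read-out lower numbers stand for stronger inhibition and higher numbers for weaker inhibition:
Compound 1 `CCOCC1=Cc2ccc(OC)cc2OC1c1cc(OC)c(OC)c(OC)c1` gives 21300 nM.
Compound 2 `CCCCNC(=O)C1=Cc2ccc(OC)cc2OC1c1cc(OC)c(OC)c(OC)c1` gives 25500 nM.
Compound 3 `COc1ccc2c(c1)OC(c1cc(OC)c(OC)c(OC)c1)C(C(=O)NC(C)C)=C2` gives only a limit of the assay, > 50000 nM.

Compound 3 thus stands at the edge of what this assay reports, with no number of its own; its entry is the limit of > 50000 nM in this assay, at which 1 of the 3 values shown sits. Compound 4 `COc1ccc2c(c1)OC(c1cc(OC)c(OC)c(OC)c1)C(C#N)=C2` differs from compound 3 in one place: cyano in place of isopropylcarbamoyl on a double-bonded ring carbon. Among the measured compounds shown here, no measured step turns any group into cyano. The steps that touch this position are a 1.2-fold higher number from compound 1 to compound 2 (0.08 log units; within the scatter) and an at least 2.3-fold higher number from compound 1 to compound 3 (0.37 log units; beyond the scatter); among the two carbamoyl compounds, an at least 1.9-fold higher number from compound 2 to compound 3 (0.29 log units; that floor lies within the scatter). Exchanges at this position have so far given flat to modestly weaker numbers, and since compound 3 itself has no number, the direction of the next step cannot be fixed from the data. In this assay compound 4 is expected near 40000 nM, with a range of 12000 nM to 150000 nM. The expected step is an at least 1.2-fold lower number from compound 3 to compound 4 (0.09 log units; that floor lies within the scatter), within the scatter, and a repeat of a limit for compound 4 is quite possible.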

Compound 4, half-maximal inhibitory concentration: 3400 nM
The estimate for compound 4 lay 12-fold (1.07 log units) above the measured number; the whole stated range lies above it.
By their numbers in this assay, from the lowest: compound 4; then compounds 1 and 2 (each within the scatter of the next). At a limit, above all of these: compound 3.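

On the double-bonded ring carbon, cyano is the first group shown to bring the number clearly down in this assay, whereas exchanges among ethoxymethyl, butylcarbamoyl and isopropylcarbamoyl gave only flat or modestly weaker readings. The change gives a 6.3-fold lower number from compound 1 to compound 4 (0.80 log units; beyond the scatter), a 7.5-fold lower number from compound 2 to compound 4 (0.88 log units; beyond the scatter) and an at least 14-fold lower number from compound 3 to compound 4 (1.16 log units; beyond the scatter), so all three earlier groups read weaker than cyano at this position. Compound 3 is entered only as a limit, so the last of these steps is a floor: the limit of > 50000 nM in this assay, at which 1 of the 4 values shown sits.

With cyano present in compound 4 alone, the compounds shown do not separate any contribution of the nitrile from the loss of the other groups. On these data alone, how a carboxylic acid, an unsubstituted carboxamide or an aminomethyl group would read on this carbon remains open.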